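The compounds below may be only part of what the source reports. "The series", "measured", "known", "first", "only" and "open" are said of these compounds alone.

Going by the values given here, in an ADME assay on HeLa cells (Homo sapiens) for cytotoxicity, read by MTT assay (on this read-out higher numbers stand for weaker inhibition and lower numbers for stronger inhibition), compound 1 `COc1ccc(C[C@H]2COC(=O)[C@@H]2Cc2ccc(OCC(=O)Nc3ccc(C)cc3)c(OC)c2)cc1OC` gives 228000 nM, the lowest of the three numbers measured so far. Compound 2 `COc1ccc(C[C@H]2COC(=O)[C@@H]2Cc2ccc(OCc3cn(-c4cccc(Cl)c4)nn3)c(OC)c2)cc1OC` gives 493000 nM and compound 3 `COc1ccc(C[C@H]2COC(=O)[C@@H]2Cc2ccc(OCc3cn(Cc4ccccc4)nn3)c(OC)c2)cc1OC` gives 346000 nM. The step of a 2.2-fold higher number from compound 1 to compound 2 (0.33 log units; beyond the scatter) lies beyond the scatter, whereas a 1.5-fold higher number from compound 1 to compound 3 (0.18 log units; within the scatter) and a 1.4-fold lower number from compound 2 to compound 3 (0.15 log units; within the scatter) do not. Compound 4 `COC(=O)CNC(=O)CCC(=O)Oc1ccc(C[C@H]2C(=O)OC[C@@H]2Cc2ccc(OC)c(OC)c2)cc1OC` differs from compound 1 in that (a group of 12 heavy atoms (7 carbon, 1 nitrogen, 4 oxygen; no ring) in place of a group of 11 heavy atoms (9 carbon, 1 nitrogen, 1 oxygen; one six-membered aromatic ring of carbon only), on an oxygen on an aromatic ring). Among the compounds with values here, both measured changes at this oxygen removed the same group and moved the number little, and no measured step introduces a chain without a ring, so in this assay the expected step is a 1.3-fold higher number from compound 1 to compound 4 (0.12 log units; within the scatter), within the scatter. Compound 4 is therefore expected to give about 300000 nM, within a range of 150000 nM to 600000 nM.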

Compound 4, half-maximal inhibitory concentration: 179000 nM
For compound 4 the middle estimate is 1.7-fold (0.22 log units) above the measured one; measured number inside the range.
By their numbers in this assay, from the lowest: compounds 4, 1, 3 and 2 (each within the scatter of the next, the first and the last beyond it).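

With a chain that has no ring entering on the oxygen on an aromatic ring, this assay gives a 1.3-fold lower number from compound 1 to compound 4 (0.11 log units; within the scatter). The ((4-methylphenyl)carbamoyl)methyl group can therefore be replaced not only by the triazole-bearing groups of compound 2 and compound 3 but also by this ring-free group of 12 heavy atoms, without a step beyond the scatter. Nothing available explains why the number holds across this change. The compounds shown leave open whether a chain ending in a carboxylic acid or an amine, or a much longer chain, would give a step beyond the scatter.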